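A few compounds are considered here, and "the series" means these few. Any claim that something is new, unique, unknown or untested is made for them only; others in the source may bear on it.

Working notes on the series built on the core of compound 1 `C=CNCc1cc(-c2c(C(=O)NCC)noc2-c2cc(C(C)C)c(O)cc2O)on1` follow. Going by the values given here, in a functional assay on A2780 cells (Homo sapiens) for inhibition (on this read-out lower numbers stand for stronger inhibition and higher numbers for weaker inhibition), compound 1 gives 43 nM and remains the only number available. Compound 2 `CCNC(=O)c1noc(-c2cc(C(C)C)c(O)cc2O)c1-c1cc(CNC(=O)CC)no1` carries the entry "not determined" (no result reported) on this read-out, and compound 3 `CCNC(=O)c1noc(-c2cc(C(C)C)c(O)cc2O)c1-c1cc(CNCCO)no1` carries the entry "not determined" (no result reported) as well. Compound 3 therefore has no value of its own to serve as a starting point.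

Compound 4 `CCNC(=O)c1noc(-c2cc(C(C)C)c(O)cc2O)c1-c1cc(C(=O)O)no1` has carboxy in place of ((2-hydroxyethyl)amino)methyl on an aromatic carbon of the five-membered aromatic ring with 1 nitrogen and 1 oxygen. Among the compounds with values here, no measured step covers this change, so the expectation is a judgement with wide uncertainty. In this assay compound 4 is expected to be clearly weaker than compound 1 at 43 nM in a step well beyond the scatter, not a small shift. In this assay the estimated value for compound 4 is 400 nM with an expected range of 80 nM to 2500 nM for the measurement to come.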

Compound 4, half-maximal inhibitory concentration: 20000 nM
For compound 4 the middle estimate is 50-fold (1.70 log units) below the measured one; measured number outside the range, above it.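

Going by these compounds alone, on the aromatic carbon next to the ring nitrogen, this assay now gives a first step at this position: carboxy in place of (vinylamino)methyl gives a 470-fold higher number from compound 1 to compound 4 (2.67 log units; beyond the scatter) with the rest of the structure unchanged. This position is therefore not indifferent to the group it carries, which compound 1 alone could not show. No measurement of any property bears on this result, so the data shown give no reason for the step.

Compound 2 and compound 3 carry no number, so the step from compound 3 to compound 4 cannot be read. Going by these compounds, whether the loss belongs to the carboxylic acid itself or to the absence of the aminomethyl link stays open, and a methyl ester, a primary amide or an unsubstituted aminomethyl group at this place would separate the two.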